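The source may hold more compounds than are shown below. What is called first, only, known or untested is meant among the compounds shown, and "the series" means these compounds.

Measured so far:
- compound 1, `CC(C)Oc1ccc(-c2nc(N)nc(NCc3ccccc3)n2)c(CO)c1`: in a functional assay on cells for positive allosteric modulation of G-protein coupled receptor 68 (Homo sapiens), read by a luciferase reporter and cAMP accumulation, with a stated time of 30 min, at pH 6.8 and pH 8.3, in the presence of a further agent that is not named here (a lower number here means a less potent compound, a higher number a more potent compound, by a factor of ten per unit of this negative logarithm), compound 1 gives 4.91
- compound 2, `Nc1nc(NCc2ccccc2F)nc(-c2ccccc2CO)n1`: in this assay compound 2 gives 4.27

Compound 2 holds the lower of the two numbers; compound 1 sits higher, and the gap between the two lies beyond the scatter, but the two structures differ in more than one place, so no single step can be read from them.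

Compound 3, `Cc1cccc(CNc2nc(N)nc(-c3ccccc3CO)n2)c1`, differs from compound 2 in one place: 3-methylphenyl in place of 2-fluorophenyl on a saturated chain carbon bound to a nitrogen on an aromatic ring. The change swaps one substituent for another of the same size on the same ring, with no donors or acceptors gained or lost. Going by the values given here, no measured pair shows what such a swap does here, so the expected step from compound 2 to compound 3 in this assay is small, a number 0.23 log units higher from compound 2 to compound 3 (within the scatter), and not clearly beyond the scatter in either direction. On that basis compound 3 is estimated at 4.5 in this assay, within a range of 3.9 to 5.2.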

Compound 3, negative logarithm of the antagonist equilibrium constant: 4.4
Compound 3: the middle estimate sits 0.10 log units above what was measured; low and high end bracket the measured number.
By their numbers in this assay, from the lowest: compounds 2 and 3 (each within the scatter of the next); then compound 1.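

Going by these compounds alone, this is the first step that can be read at a single place: in this assay, 3-methylphenyl in place of 2-fluorophenyl on a saturated chain carbon bound to a nitrogen on an aromatic ring gives a number 0.13 log units higher from compound 2 to compound 3 (within the scatter). At this place, the two substituted phenyl groups therefore cannot be told apart in this read-out, so the exchange of a fluorine for a methyl group on the ring, at a different ring position, has no resolved effect. No available measurement bears on the reason for this result.

Steps linking compound 1 to compound 2 or compound 3 cannot be read, as those structures differ in more than one place. Still open, from the compounds shown here alone, is how this place responds to groups unlike these two, such as a phenyl ring carrying a carboxylic acid or an amine, or a longer chain.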